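A few compounds are considered here, and "the series" means these few. Any claim that something is new, unique, unknown or untested is made for them only; others in the source may bear on it.

Working notes on the series, cytotoxicity read-out.

Compound 3 `CC(=O)c1ccc(NC(=O)CSc2snnc2-c2ccc(Br)cc2Br)c(Br)c1` reaches only a limit in an ADME assay on MT4 cells (Homo sapiens) for cytotoxicity, read by MTT assay, with a stated time of 5 days (on this read-out higher numbers stand for lower toxicity in this test and lower numbers for higher toxicity in this test), namely > 206000 nM. Compound 1 `Cc1cccc(C)c1NC(=O)CSc1snnc1-c1ccc(Br)cc1Br` likewise sits at a limit in this assay, >= 198000 nM. Within the data shown here, compound 2 `O=C(CSc1snnc1-c1ccc(Br)cc1Br)Nc1ccccc1` is the one member with a numerical value in this assay, 24800 nM. Compound 3 therefore stands with the less toxic end of the three, where the limit of > 206000 nM in this assay, at which 1 of the 3 values shown sits, and the limit of >= 198000 nM in this assay, at which 1 of the 3 values shown sits, mark the upper edge of what this assay resolves. Among the measured compounds shown here, the single readable step, an at least 7.9-fold lower number from compound 1 to compound 2 (0.90 log units; beyond the scatter), concerns the amide-side ring and not the acetyl-bearing position.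

Compound 4 `Cc1ccc(NC(=O)CSc2snnc2-c2ccc(Br)cc2Br)c(Br)c1` differs from compound 3 by methyl in place of acetyl on an aromatic carbon. For the measured compounds named here, no measured step removes an acetyl, so the step of an at least 1.3-fold lower number from compound 3 to compound 4 (0.13 log units; that floor lies within the scatter) is expected to be small, with compound 4 staying near the limit; a drift toward the value of compound 2 cannot be excluded, since compound 2 carries no such substituent either. Compound 4 is estimated at 150000 nM in this assay, within a range from 40000 nM to 300000 nM.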

Compound 4, half-maximal cytotoxic concentration: > 216000 nM
Compound 4 ended at the assay's limit; the forecaster's own chance of this, stated with the estimate: 60%; middle value at least 1.4-fold (0.15 log units) from the limit.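

Compound 4, with methyl in place of acetyl on an aromatic carbon, also gives a limit and not a number in this assay: the limit of > 216000 nM in this assay, at which 1 of the 4 values shown sits. The steps to compound 4 from compound 3 and from compound 1 join limit to limit and cannot be read. Among these compounds, the one readable step, an at least 8.7-fold higher number from compound 2 to compound 4 (0.94 log units; beyond the scatter), comes with 2-bromo-4-methylphenyl in place of phenyl on an amide-type nitrogen, and it shows that the acetyl of compound 3 is not required for a reading at the limit.

Any difference between acetyl and methyl at this position stays hidden behind the two limits. Also open, on these data alone, is how an amine or a carboxylic acid would read on this aromatic carbon, and whether any group there brings the number back towards that of compound 2.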